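A few compounds are considered here, and "the series" means these few. Any claim that something is new, unique, unknown or untested is made for them only; others in the source may bear on it.

Working notes on the series, measured in a toxicity assay on Huh-7.5 cells (Homo sapiens) for inhibition, read by MTT assay, with a stated time of 96 h; on this read-out higher numbers stand for lower toxicity in this test and lower numbers for higher toxicity in this test:
- compound 1 `CN1CCN(Cc2ccc(NC(=O)c3ccc(OCCCCl)c(Cl)c3)cc2C(F)(F)F)CC1` gives 4100 nM
- compound 2 `CN1CCN(Cc2ccc(NC(=O)c3ccc(OCCCCCCl)c([N+](=O)[O-])c3)cc2C(F)(F)F)CC1` gives 2140 nM
- compound 3 `CCC(=O)Nc1cc(C(=O)Nc2ccc(CN3CCN(C)CC3)c(C(F)(F)F)c2)ccc1OC(C)C` gives 15300 nM

Compound 2 stands at the low end of these three numbers. It lies within the scatter of compound 1 and beyond the scatter from compound 3.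

Next is compound 4 `CN1CCN(Cc2ccc(NC(=O)c3ccc(OCCCl)c([N+](=O)[O-])c3)cc2C(F)(F)F)CC1`, not yet measured in this assay. Relative to compound 2, the change is chloro in place of 3-chloropropyl on a saturated chain carbon, two bonds along the chain from an oxygen on an aromatic ring. In effect, (5-chloropentyl)oxy becomes 2-chloroethoxy.

Among the compounds with values here, no measured pair isolates this change. Within the data shown here, the only indirect guide is compound 1 at 4100 nM, which carries a 3-chloropropyl chain but also differs from compound 2 elsewhere. A modest move towards a higher number is therefore expected, of a size close to the scatter: the estimated step is a 2.0-fold higher number from compound 2 to compound 4 (0.30 log units; within the scatter).

For compound 4 the expected value is 4300 nM, with an estimated range of 1900 nM to 10000 nM.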

Compound 4, half-maximal cytotoxic concentration: 9040 nM
Beside the measured number, compound 4's estimate is 2.1-fold (0.32 log units) below it; the measured number falls inside the stated range.
By their numbers in this assay, from the lowest: compounds 2 and 1 (each within the scatter of the next); then compounds 4 and 3 (each within the scatter of the next).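

In this assay, within the data shown here, the change from (5-chloropentyl)oxy to 2-chloroethoxy gives the first comparison that differs in one place only, and it reads as a 4.2-fold higher number from compound 2 to compound 4 (0.63 log units; beyond the scatter) on the shared core. This chain position therefore affects the read-out: with the rest of the structure held constant, chloro in place of 3-chloropropyl goes with lower toxicity in this test. Nothing available explains this step.

From the compounds shown here alone, with only these two chain lengths on this core, it remains open whether the number changes evenly with chain length or only at a particular length. Also open, going by these compounds, is how the read-out responds when this chain ends in an amine or a carboxylic acid instead of chlorine.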